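Para Substituent Swap on a Furanyl Triazolopyrimidine Acid

The source may hold more compounds than are shown below. What is called first, only, known or untested is meant among the compounds shown, and "the series" means these compounds.

Compound 1 `O=C(O)c1cnc(NCc2ccc(F)cc2)n2nc(-c3ccco3)nc12`: > 30000 nM in a functional assay on CHO cells for antagonist activity at adenosine receptor A2b (Homo sapiens) (on this read-out higher numbers stand for weaker inhibition and lower numbers for stronger inhibition), a limit of the assay.
Compound 2 `O=C(O)c1cnc(NCc2ccc(Cl)cc2)n2nc(-c3ccco3)nc12`: > 30000 nM in this assay, likewise a limit.

Compound 2 therefore stands only at the limit of > 30000 nM in this assay, at which 2 of the 2 values shown sit. Compound 3 `O=C(O)c1cnc(NCc2ccc(C(F)(F)F)cc2)n2nc(-c3ccco3)nc12` differs by trifluoromethyl in place of chloro on an aromatic carbon. Among the measured compounds shown here, the sole measured step, a step that the two limits leave unreadable from compound 1 to compound 2, cannot be sized because both ends sit at the limit of > 30000 nM in this assay, at which 2 of the 2 values shown sit, so it gives no direction for the new change. With nothing beyond two limits to build on, compound 3 is expected to remain weak, with a step that the limit leaves unreadable from compound 2 to compound 3 not readable beyond the scatter. The estimate for compound 3 is 50000 nM, ranging from 15000 nM to 200000 nM.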

Compound 3, inhibition constant: > 30000 nM
Compound 3: only a limit was reported (the forecaster's own chance of this, stated with the estimate: 85%); the middle value does not contradict the limit.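

Compound 3 gives no readable step from compound 1 or compound 2, as all three compounds sit at one limit: the limit of > 30000 nM in this assay, at which 3 of the 3 values shown sit.

As far as these compounds go, how strongly compound 1, compound 2 and compound 3 act in this assay, and whether fluoro, chloro and trifluoromethyl differ at all, remains open.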